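The compounds below may be only part of what the source reports. "The series", "measured", "known", "first", "only" and "open" are said of these compounds alone.

Measured so far:
- compound 1 `Cc1nc(N(C)C(=O)NC(=O)c2c(F)cccc2F)sc1C(=O)N/N=C/c1ccccc1C(F)(F)F` — 1.11 ug/mL
- compound 2 `CN(C(=O)NC(=O)c1c(F)cccc1F)c1nc(C(F)(F)F)c(C(=O)N/N=C/c2ccc(C(F)(F)F)cc2)s1` — 49.6 ug/mL

Both compounds were tested in a functional assay on HepG2 cells (Homo sapiens) for inhibition, read by MTT assay, with a stated time of 72 h; a higher number here means a weaker inhibitor, a lower number a stronger inhibitor. Of the two numbers, compound 2 has the higher one, and compound 1 lies far beneath it; the gap between them is well beyond the usual scatter, so compound 2 is the weaker inhibitor of the pair. Compound 3 `Cc1nc(N(C)C(=O)NC(=O)c2c(F)cccc2F)sc1C(=O)N/N=C/c1ccc(C(F)(F)F)cc1` has not yet been measured. It differs from compound 2 in one place: methyl in place of trifluoromethyl on an aromatic carbon, a methyl in place of trifluoromethyl on an aromatic carbon of the shared core. Within the data shown here, no measured pair shows exactly this change on its own, so the size of the step cannot be read from the data directly. Compound 1, however, already carries the methyl at that spot and gives a much lower number than compound 2, though it differs from compound 3 elsewhere as well. On this basis the number for compound 3 is expected to fall, with a step from compound 2 to compound 3 of about a 9.9-fold lower number from compound 2 to compound 3 (1.00 log units; beyond the scatter) estimated. The estimate for compound 3 is 5 ug/mL, with a range from 1 ug/mL to 30 ug/mL.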

Compound 3, half-maximal inhibitory concentration: > 100 ug/mL
Compound 3 ended at the assay's limit (the forecaster's own chance of this, stated with the estimate: 10%); at least 20-fold (1.30 log units) between middle value and limit.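

In this assay compound 3 gives > 100 ug/mL, which is a limit of the assay and not a number. Placing methyl instead of trifluoromethyl on the aromatic carbon next to the ring nitrogen brings no drop in the number here: the step is an at least 2.0-fold higher number from compound 2 to compound 3 (0.30 log units; that floor lies within the scatter), and because this is only a floor, it shows the direction of the change at most weakly and sets no size for it. Moving the trifluoromethyl on the phenyl group, with 4-(trifluoromethyl)phenyl in place of 2-(trifluoromethyl)phenyl, gives an at least 90-fold higher number from compound 1 to compound 3 (1.95 log units; beyond the scatter), so among these compounds the low number goes with the 2-(trifluoromethyl)phenyl group, and methyl on the core does not give it alone.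

From the compounds shown here alone, how far the real number of compound 3 lies past the cut-off stays unknown, and so does the full size of both steps: the limit of > 100 ug/mL in this assay, at which 1 of the 3 values shown sits. Also open, going by these compounds, is whether the 2-(trifluoromethyl)phenyl group keeps its low number with trifluoromethyl on the core, and how a plain hydrogen, an ethyl chain or an amine on that same aromatic carbon would compare with methyl.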